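Formyl to hydroxymethyl: working notes on the series

This account rests on a few compounds, and the source may have more. Where it says the series, first, only, none or still open, it means among the compounds named here.

Measured in a functional assay on KB 3-1 cells (Homo sapiens) for cytotoxicity, read by MTT assay, with a stated time of 68 h, tested at 5 uM; on this read-out higher numbers stand for weaker inhibition and lower numbers for stronger inhibition:
- compound 1 `CC1(C)O[C@@H]2CC[C@](C)(O)[C@H](CCC3C(C=O)=CCC4C(CC[C@@]4(C)O)C3(C)C)[C@@]2(C)CCC1=O`: 5.6 nM
- compound 2 `CC1(C)C(CC[C@@H]2[C@@]3(C)CC[C@@H](O)C(C)(C)O[C@@H]3CC[C@]2(C)O)C(C=O)=CCC2C1CC[C@@]2(C)O`: 5 nM

Compound 2, at 5 nM, stands level with compound 1, at 5.6 nM. The two numbers lie within the scatter of each other, so neither can be ranked above the other.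

The next step leads to compound 3 `CC1(C)C(CC[C@@H]2[C@@]3(C)CC[C@@H](O)C(C)(C)O[C@@H]3CC[C@]2(C)O)C(CO)=CCC2C1CC[C@@]2(C)O`, which has hydroxymethyl in place of formyl on a double-bonded ring carbon. Within the data shown here, no measured pair shows this change, so the data give no direct size for it. The expectation is therefore tentative: a moderate move in this assay towards a higher number, meaning weaker inhibition. The expected change is a 6.0-fold higher number from compound 2 to compound 3 (0.78 log units; beyond the scatter). For compound 3 the estimated value is 30 nM, with an expected range of 5 nM to 300 nM.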

Compound 3, half-maximal inhibitory concentration: 5.9 nM
Compound 3: the middle estimate sits 5.1-fold (0.71 log units) above what was measured; the range from low to high includes it.
By their numbers in this assay, from the lowest: compounds 2, 1 and 3 (each within the scatter of the next).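

In this assay, putting hydroxymethyl in place of formyl on a double-bonded ring carbon gives a 1.2-fold higher number from compound 2 to compound 3 (0.07 log units; within the scatter) and so sets the first measured size for this change; compound 2 and compound 3 cannot be ranked. On this core, the formyl group is therefore not required at this position for a low nanomolar reading, since compound 3, which has hydroxymethyl there and gains a hydrogen-bond donor, gives 5.9 nM in this assay. No measurement at hand accounts for this result.

On these data alone, whether the position also accepts a carboxylic acid, an amine or a longer chain remains open. As far as these compounds go, it is equally open whether hydroxymethyl would read the same on the core of compound 1, and a single pair cannot show how general the result is.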